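The source may hold more compounds than are shown below. What is called first, only, known or untested is meant among the compounds shown, and "the series" means these compounds.

Measured so far:
compound 1 `Nc1ncnc2c1c(-c1cnc3[nH]ccc3c1)nn2CCCCCCCCC(=O)NO` - 2270 nM
compound 2 `Nc1nc2cc(-c3nn(CCCCC(=O)NO)c4ncnc(N)c34)ccc2o1` - > 50000 nM

Among the compounds with values here, in a functional assay on CNE-2 cells (Homo sapiens) for inhibition, read by MTT assay, with a stated time of 72 h (a lower number here means a stronger inhibitor, a higher number a weaker inhibitor), compound 1 gives 2270 nM, the only actual number so far. For compound 2 the reading of > 50000 nM is a limit of the assay. Compound 3 `Nc1ncnc2c1c(-c1cnc3[nH]ccc3c1)nn2CCC(=O)NO` keeps the core of compound 1 but carries hydroxycarbamoyl in place of 6-(hydroxycarbamoyl)hexyl on a saturated chain carbon, two bonds along the chain from an aromatic nitrogen. Within the data shown here, no measured step covers this change, so its size is uncertain. A clear weakening in this assay, well beyond the scatter, is expected. The estimated change is a 13-fold higher number from compound 1 to compound 3 (1.12 log units; beyond the scatter). For compound 3 the expected value is 30000 nM, with an estimated range from 8000 nM to 80000 nM.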

Compound 3, half-maximal inhibitory concentration: > 150000 nM
Compound 3 was reported as a limit (the forecaster's own chance of this, stated with the estimate: 50%); middle value at least 5.0-fold (0.69 log units) from the limit.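

Hydroxycarbamoyl in place of 6-(hydroxycarbamoyl)hexyl, on a saturated chain carbon, two bonds along the chain from an aromatic nitrogen, gives the first measured step at this position: in this assay it is an at least 66-fold higher number from compound 1 to compound 3 (1.82 log units; beyond the scatter). On the core of compound 1, the long chain thus matters greatly to the reading in this pair. The reading for compound 3 is a limit, not a number: the limit of > 150000 nM in this assay, at which 1 of the 3 values shown sits.

Chains of intermediate length and a longer chain remain open on this core. So does whether a carboxylic acid or an amine at the chain end would keep the reading of compound 1.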